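A methoxy swap on the weaker growth inhibitor

The source may report more compounds than this note shows. Statements on the series, on what has been measured and on what is new or still open speak of the compounds shown alone.

In a functional assay on DU-145 cells (Homo sapiens) for inhibition, read by trypan blue exclusion, with a stated time of 96 h (on this read-out lower numbers stand for stronger inhibition of growth and higher numbers for weaker inhibition of growth), compound 1 `Cc1ccc(CS(=O)(=O)/C(=C/c2ccccc2OCc2ccccc2)C(=O)c2ccc(Cl)cc2)cc1` gives 1000 nM and compound 2 `O=C(/C(=C\c1ccccc1F)S(=O)(=O)c1ccc(Br)cc1)c1ccc(Cl)cc1` gives 25000 nM as the higher of the two numbers, which means weaker inhibition of growth. Compound 3 `COc1ccc(/C=C(\C(=O)c2ccc(Cl)cc2)S(=O)(=O)c2ccc(Br)cc2)cc1` carries 4-methoxyphenyl in place of 2-fluorophenyl on a double-bonded chain carbon bound to a double-bonded chain carbon (a change of 4-methoxyphenyl in place of 2-fluorophenyl on a double-bonded chain carbon bound to a double-bonded chain carbon). Going by the values given here, no measured pair shows this swap. A modest move towards stronger inhibition is expected, with a 3.1-fold lower number from compound 2 to compound 3 (0.49 log units; beyond the scatter) as the estimated step. Compound 3 is estimated at 8000 nM in this assay as the expected value (range 1500 nM to 30000 nM).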

Compound 3, concentration for 50% growth inhibition: 10000 nM
Beside the measured number, compound 3's estimate is 1.3-fold (0.10 log units) below it; the measured number falls inside the stated range.
By their numbers in this assay, from the lowest: compound 1; then compound 3; then compound 2.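

In this assay, going by these compounds alone, 4-methoxyphenyl in place of 2-fluorophenyl gives a 2.5-fold lower number from compound 2 to compound 3 (0.40 log units; beyond the scatter), the first comparison in which only this position differs, and it shows that growth inhibition responds to the group placed here. The swap replaces fluorine with methoxy and also changes where the substituent sits on the ring, so this single step cannot separate those two changes. No available evidence explains the shift. As far as these compounds go, it remains open how a 4-aminophenyl or 4-carboxyphenyl group would behave here, and whether the same swap would have a similar effect on the core of compound 1.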